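Fluorine position on the arylidene arm of the shared core

The source may hold more compounds than are shown below. What is called first, only, known or untested is meant among the compounds shown, and "the series" means these compounds.

Measured compounds:
- compound 1 `COc1ccccc1/C=c1\c(=O)[nH]/c(=C/c2cccc(Cl)c2Cl)c(=O)n1C`: 200 nM
- compound 2 `C=CCn1c(=O)/c(=C\c2ccc(Cl)c(Cl)c2)[nH]c(=O)/c1=C\c1ccccc1`: "not active" (no number reported)
- compound 3 `C=CCn1c(=O)/c(=C\c2cccc(F)c2)[nH]c(=O)/c1=C\c1ccccc1OC`: 19700 nM

In a functional assay on A549 cells (Homo sapiens) for cytotoxicity, read by CCK-8 assay, with a stated time of 72 h (on this read-out lower numbers stand for stronger inhibition and higher numbers for weaker inhibition), compound 3 gives 19700 nM, the higher of the two numbers recorded in this assay. Compound 1 gives 200 nM, a far lower number; the gap between compound 1 and compound 3 lies well beyond the usual scatter of this assay. Compound 2 is reported in this assay as "not active" (no number reported), with no number attached.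

Compound 4 `C=CCn1c(=O)/c(=C\c2ccccc2F)[nH]c(=O)/c1=C\c1ccccc1OC` has not been measured. It differs from compound 3 in one place: 2-fluorophenyl in place of 3-fluorophenyl on a double-bonded chain carbon bound to an aromatic carbon. Within the data shown here, the compounds measured so far give no direct step for this change, and compound 1 and compound 2 carry chlorine substituents rather than fluorine, so they do not settle the question. Only a small step is expected, in either direction or none beyond the scatter; the step from compound 3 to compound 4 is estimated at a 1.3-fold lower number from compound 3 to compound 4 (0.12 log units; within the scatter). Compound 4 is therefore expected to give about 15000 nM in this assay, within a range of 3000 nM to 60000 nM.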

Compound 4, half-maximal inhibitory concentration: "not active" (no number reported)
Compound 4 has no reported number here, and the estimate cannot be compared.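

Among these compounds, compound 4 is reported as "not active" without a number, so no step from compound 3 to it can be read. No supporting evidence bears on this result. As far as these compounds go, how far 2-fluorophenyl in place of 3-fluorophenyl shifts the number remains open.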